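Dihydroindolyl Replaces Morpholinyl on a Weak Sulfamoyl Carbamate

The source may hold more compounds than are shown below. What is called first, only, known or untested is meant among the compounds shown, and "the series" means these compounds.

Going by the values given here, compound 1 `CC(C)c1cccc(C(C)C)c1OC(=O)NS(=O)(=O)N1CCCC1` is the only member with a number: in an assay on liver for inhibition of sterol O-acyltransferase 1 (Rattus norvegicus), using microsomes (a lower number here means a stronger inhibitor, a higher number a weaker inhibitor), compound 1 gives 53000 nM. Compound 2 `CC(C)c1cccc(C(C)C)c1OC(=O)NS(=O)(=O)N1CCCCC1` stops at the assay limit, > 100000 nM. Compound 3 `CC(C)c1cccc(C(C)C)c1OC(=O)NS(=O)(=O)N1CCOCC1` likewise stops at the assay limit, > 100000 nM. Compound 3 thus sits where most of the series sits, at the limit of > 100000 nM in this assay, at which 2 of the 3 values shown sit. The measured steps run an at least 1.8-fold higher number from compound 1 to compound 2 (0.27 log units; that floor lies within the scatter) and an at least 1.8-fold higher number from compound 1 to compound 3 (0.27 log units; that floor lies within the scatter), while a step that the two limits leave unreadable from compound 2 to compound 3. Compound 4 `CC(C)c1cccc(C(C)C)c1OC(=O)NS(=O)(=O)N1CCc2ccccc21` differs from compound 3 by 2,3-dihydro-1H-indol-1-yl in place of morpholin-4-yl on a sulfonyl sulfur. Among the compounds with values here, none of the measured steps brings in an aromatic ring, and both steps ending at compound 3 are limits, so the expected step of an at least 2.0-fold lower number from compound 3 to compound 4 (0.30 log units; that floor lies within the scatter) is held loosely. Compound 4 is estimated at 50000 nM, with a range from 8000 nM to 200000 nM.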

Compound 4, half-maximal inhibitory concentration: 43000 nM
Compound 4: middle estimate off by 1.2-fold (0.07 log units), on the high side; the range from low to high includes it.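

Going by these compounds alone, the 2,3-dihydro-1H-indol-1-yl group gives the first steps that lie beyond the scatter: an at least 2.3-fold lower number from compound 3 to compound 4 (0.36 log units; beyond the scatter) and an at least 2.3-fold lower number from compound 2 to compound 4 (0.36 log units; beyond the scatter). Both are only floors, set by a limit of the assay: the limit of > 100000 nM in this assay, at which 2 of the 4 values shown sit. Against the pyrrolidin-1-yl member the change amounts to a 1.2-fold lower number from compound 1 to compound 4 (0.09 log units; within the scatter), so an aromatic ring on this sulfonyl sulfur leaves the two compounds level.

As far as these compounds go, what a methoxy group or a carboxylic acid on that aromatic ring would do stays open. So does the effect of an open-chain diethylamino group on the sulfonyl sulfur.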